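This account rests on a few compounds, and the source may have more. Where it says the series, first, only, none or still open, it means among the compounds named here.

Measured in an ADME assay on microsomes from liver (Mus musculus) for metabolic stability, read by LC-MS, using NADPH, with a stated time of 10 min, tested at 0.1 uM; on this read-out lower numbers stand for slow clearance and higher numbers for fast clearance:
- Compound 1 `CC1SC(c2cccc(C(=O)NCCCCc3ccccc3)c2)N(c2ccc(C3CC3)cc2)C1=O`: 3210 mL.min-1.g-1
- Compound 2 `COc1ccc(F)cc1N1C(=O)CSC1c1cccc(C(=O)NCCCCn2cccn2)c1`: 1310 mL.min-1.g-1
- Compound 3 `COc1ccc(F)cc1N1C(=O)CSC1c1cccc(C(=O)NCCCCc2ccccc2)c1`: 2250 mL.min-1.g-1

In this assay compound 3, at 2250 mL.min-1.g-1, lies within the usual scatter of both compound 1 and compound 2. Compound 4 `Cc1cccc(N2C(=O)CSC2c2cccc(C(=O)NCCCCc3ccccc3)c2)c1` has 3-methylphenyl in place of 5-fluoro-2-methoxyphenyl on an amide-type nitrogen in a ring. Going by the values given here, no measured pair isolates this change. Compound 1 differs from compound 3 at that nitrogen, but also in a second place. Among the compounds with values here, the one measured step, a 1.7-fold higher number from compound 2 to compound 3 (0.23 log units; within the scatter), lies elsewhere, on the chain, and stays within the scatter. No step beyond the scatter is therefore expected in this assay, and the estimated move is a 1.2-fold higher number from compound 3 to compound 4 (0.06 log units; within the scatter). The estimate for compound 4 is 2600 mL.min-1.g-1, with an expected range of 1300 mL.min-1.g-1 to 5000 mL.min-1.g-1.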

Compound 4, intrinsic clearance in microsomes: 2940 mL.min-1.g-1
Compound 4: middle estimate off by 1.1-fold (0.05 log units), on the low side; measured number inside the range.
By their numbers in this assay, from the lowest: compounds 2, 3, 4 and 1 (each within the scatter of the next, the first and the last beyond it).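

In this assay, the exchange on the amide-type nitrogen in the ring now has a pair that isolates it: 3-methylphenyl in place of 5-fluoro-2-methoxyphenyl gives a 1.3-fold higher number from compound 3 to compound 4 (0.12 log units; within the scatter). At this position, then, the two aryl groups cannot be told apart in this read-out, a reading that compound 1 could not give, as it differs from compound 3 in a second place as well. Nothing measured here speaks to the reason for this. Still open, as far as these compounds go, is whether an amine or a carboxylic acid on this phenyl ring would give a step beyond the scatter, and whether 3-methylphenyl would behave alike with the 1H-pyrazol-1-yl chain of compound 2.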